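The compounds below may be only part of what the source reports. "The series", "measured", "known", "first", "only" and "open" are said of these compounds alone.

Three compounds of related build were measured in an in vitro assay on BTI-TN-5B1-4 cells for inhibition of Amine oxidase [flavin-containing] B (Homo sapiens); a higher number here means a weaker inhibitor, a lower number a stronger inhibitor. Compound 3, `COc1ccc(-c2cc(=S)c3ccccc3o2)cc1`, gives 480 nM. Compound 1, `COc1ccc(-c2cc(=S)c3ccc(OC)cc3o2)cc1`, gives 3340 nM. Among the compounds with values here, the single change between them, (methoxy in place of hydrogen on an aromatic carbon), brought a 7.0-fold higher number from compound 3 to compound 1 (0.84 log units; beyond the scatter). Compound 2, `COc1ccc2c(c1)OC(c1ccccc1)CC2=O`, gives 1470 nM in this assay; how its core differs from that of compound 3 is not broken down here.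

Compound 4, `COc1ccc(C2CC(=O)c3ccc(OC)cc3O2)cc1`, has not yet been measured. It is derived from compound 2 by methoxy in place of hydrogen on an aromatic carbon. Within the data shown here, this is the same kind of change as the one from compound 3 to compound 1, but not the same: there the methoxy entered on a ring that is part of a fused or bridged system of two rings, meta to a fused ring and para to a fused ring, whereas here it enters on a ring of carbon only, para to a large group. Among the measured compounds shown here, because the only measured example, a 7.0-fold higher number from compound 3 to compound 1 (0.84 log units; beyond the scatter), weakened inhibition clearly, a step of a 2.4-fold higher number from compound 2 to compound 4 (0.38 log units; beyond the scatter) in this assay is expected from compound 2 to compound 4, though the different place and core leave the size uncertain. Compound 4 is therefore expected to give about 3500 nM, between 1000 nM and 12000 nM.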

Compound 4, half-maximal inhibitory concentration: 7180 nM
Estimate against measurement, compound 4: 2.1-fold (0.31 log units) below; measured number inside the range.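

In this assay, placing a methoxy on an aromatic carbon again weakened inhibition, giving a 4.9-fold higher number from compound 2 to compound 4 (0.69 log units; beyond the scatter) on the core of compound 2. Set beside the earlier case on the core of compound 3, the two steps agree in direction and do not differ in size beyond what repeat measurements would produce: the same change on two cores in this assay, a 7.0-fold higher number (0.84 log units; beyond the scatter) from compound 3 to compound 1 and a 4.9-fold higher number (0.69 log units; beyond the scatter) from compound 2 to compound 4, 1.4-fold (0.15 log units) apart, within the scatter of two such steps. This shows that, in these two pairs, the loss carries over from one core to the other at much the same size, even though the methoxy enters a different ring in each, but two pairs are too few to make a rule for the whole series, and they do not show why the change weakens inhibition.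

On these data alone, it remains open whether a hydroxyl group, a fluorine atom or a longer chain such as ethoxy in the same place would also weaken inhibition. As far as these compounds go, it is also open whether the methoxy step would keep its size on cores other than these two.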